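Swapping Furan for Thiophene on a Shared Core

A few compounds are considered here, and "the series" means these few. Any claim that something is new, unique, unknown or untested is made for them only; others in the source may bear on it.

Compound 1, `COC(=O)C1=C(C)NC(=O)NC1c1cccs1`, gives 3% in an assay on membranes from HeLa cells for displacement of a labelled ligand from adenosine receptor A3 (Homo sapiens), read by scintillation counting, with a stated time of 180 min, tested at 1 uM; on this read-out higher numbers stand for more inhibition at the one concentration tested (going by the name of the read-out) and lower numbers for less inhibition.
Compound 2, `CC1=C(C(=O)C2CC2)C(c2cccs2)NC(=O)N1`, gives 15% in this assay.
Compound 3, `CC1=C(C(=O)NC(C)C)C(c2ccoc2)NC(=O)N1`, gives 3% in this assay.

Compound 3 stands level with compound 1 at the digits shown, and together these two are the lowest of the three numbers. Going by the values given here, the only single-point step measured so far, a number 12 percentage points higher from compound 1 to compound 2 (beyond the scatter), concerns the group on the carbonyl carbon, not the aromatic ring on the saturated ring carbon.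

Compound 4, `CC1=C(C(=O)NC(C)C)C(c2cccs2)NC(=O)N1`, is the next compound to be measured in this assay. It differs from compound 3 in one place: thiophen-2-yl in place of furan-3-yl on a saturated ring carbon. Among the compounds with values here, no measured step covers this exchange directly. The same thiophen-2-yl ring as in compound 4 is carried by compound 1, which gives 3%, while compound 3 with furan-3-yl gives 3%, so the two rings sit in compounds whose readings fall within the usual scatter of each other. The step is therefore expected to be small, a number 3 percentage points higher from compound 3 to compound 4 (within the scatter), with no change beyond the scatter. Compound 4 is estimated to give 6%, in a range from 0% to 20%.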

Compound 4, a percentage reported as inhibition, at one concentration (the size of the read-out at that concentration, not a potency): 1%
Compound 4: middle estimate off by 5 percentage points, on the high side; low and high end bracket the measured number.
By their numbers in this assay, from the lowest: compounds 4, 1 and 3 (each within the scatter of the next); then compound 2.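

In this assay the exchange on the saturated ring carbon now has a direct reading, a number 2 percentage points lower from compound 3 to compound 4 (within the scatter), so thiophen-2-yl and furan-3-yl cannot be told apart here while the carbonyl carbon carries isopropylamino. With thiophen-2-yl held in place, the group on the carbonyl carbon can also be compared: isopropylamino in place of cyclopropyl gives a number 14 percentage points lower from compound 2 to compound 4 (beyond the scatter), whereas isopropylamino in place of methoxy gives a number 2 percentage points lower from compound 1 to compound 4 (within the scatter), so among these three thiophen-2-yl compounds only the cyclopropyl one stands apart. Nothing measured on these compounds gives a reason for either result.

From the compounds shown here alone, the ring exchange has been read with isopropylamino alone, so it remains open whether furan-3-yl and thiophen-2-yl would also match with cyclopropyl on the carbonyl carbon, where the reading is beyond the scatter of the others. Also open, going by these compounds, is what a phenyl ring on the saturated ring carbon, or a longer chain such as n-butyl on the carbonyl carbon, would do in this single-concentration test.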